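The source may hold more compounds than are shown below. What is called first, only, known or untested is meant among the compounds shown, and "the series" means these compounds.

This account concerns three measured compounds and one yet to be measured, all assessed in a functional assay on K562 cells (Homo sapiens) for cytotoxicity, read by MTT assay, with a stated time of 72 h; a lower number here means a stronger inhibitor of growth, a higher number a weaker inhibitor of growth. Compound 1, `C[Se]/C(=N\C(=O)c1cc2ccccc2s1)NC(=O)c1cc2ccccc2s1`, gives 32400 nM. Compound 2, `C[Se]/C(=N\C(=O)c1ccco1)NC(=O)c1ccco1`, gives 8780 nM. Compound 3, `O=C(/N=C(/NC(=O)c1cc(-c2ccccc2)nc2ccccc12)[Se]Cc1ccccc1)c1cc(-c2ccccc2)nc2ccccc12`, gives 9060 nM. Among the three numbers compound 3 stands second highest: its nearest neighbour is compound 2, whose number lies within the scatter of repeated measurements, and its furthest is compound 1, whose number is higher by an amount beyond the scatter. Compound 3 and compound 2 therefore cannot be set in order against each other.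

Compound 4, `C[Se]/C(=N\C(=O)c1cc(-c2ccccc2)nc2ccccc12)NC(=O)c1cc(-c2ccccc2)nc2ccccc12`, differs from compound 3 in one place: hydrogen in place of phenyl on a saturated chain carbon bound to a selenium atom, which, read one bond further out, is a benzyl becoming a methyl. For the measured compounds named here, no measured pair in the set shows this change alone, so its size is not known from the data; compounds 1 and 2 carry a methyl rather than a benzyl, but their cores also differ from the core of compound 3, so their numbers cannot isolate the change. The step of a 1.3-fold higher number from compound 3 to compound 4 (0.12 log units; within the scatter) is expected to be small, not clearly beyond the scatter, with a slight lean toward a weaker inhibitor of growth. Compound 4 is expected to give 12000 nM, with a range from 4000 nM to 35000 nM.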

Compound 4, concentration for 50% growth inhibition: 5800 nM
Beside the measured number, compound 4's estimate is 2.1-fold (0.32 log units) above it; the measured number falls inside the stated range.
By their numbers in this assay, from the lowest: compounds 4, 2 and 3 (each within the scatter of the next); then compound 1.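

In this assay, for the compounds shown here, compound 3 and compound 4 form the first pair in which hydrogen in place of phenyl on a saturated chain carbon bound to a selenium atom, or benzyl to methyl when cut one bond further out, can be read alone, and the result is a 1.6-fold lower number from compound 3 to compound 4 (0.19 log units; within the scatter). On this shared core, the phenyl, with its 6 heavy atoms and its aromatic ring, can therefore leave this place without a difference that can be told from the scatter, so the two compounds cannot be set in order. Nothing in the data offers an explanation for this result, and the pair gives the size of the step but not its cause.

The compounds shown leave open whether the same holds on the core of compound 1 or of compound 2, since each carries the methyl and neither has a benzyl partner here. They also do not tell how this place would respond to a longer chain such as propyl, or to a benzyl bearing an amine or a carboxylic acid on its phenyl ring.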